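A Bulkier Ether in Place of an Amino Chain

The source may report more compounds than this note shows. Statements on the series, on what has been measured and on what is new or still open speak of the compounds shown alone.

Compound 1 `CCNc1cc(-c2cccnc2)ccc1C(N)=O` is the lower of the two numbers recorded in an assay on cells for inhibition of MAP kinase-interacting serine/threonine-protein kinase 1 (Homo sapiens), read by mobility shift assay, with stated times of 10 min and 60 min, in the presence of a further agent that is not named here (a lower number here means a stronger inhibitor, a higher number a weaker inhibitor), where compound 1 gives 58000 nM. Compound 2 `Cc1ncccc1-c1ccc(C(N)=O)cc1` gives 170000 nM in this assay, and the gap between the two lies beyond the usual scatter. Compound 3 `NC(=O)c1ccc(-c2cccnc2)cc1OC1CCCCC1` has not yet been measured. It differs from compound 1 in one place: cyclohexyloxy in place of ethylamino on an aromatic carbon. Within the data shown here, no step between measured compounds covers such a swap, so the expectation rests on the weak level of compound 1 alone. A modest step is expected from compound 1 to compound 3, a 1.9-fold lower number from compound 1 to compound 3 (0.29 log units; within the scatter), likely towards a somewhat lower number but not far beyond the scatter. On that basis compound 3 is estimated at 30000 nM in this assay, within a range from 6000 nM to 150000 nM.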

Compound 3, half-maximal inhibitory concentration: 1500 nM
Compound 3: middle estimate off by 20-fold (1.30 log units), on the high side; the measured number lies below the stated range.
By their numbers in this assay, from the lowest: compound 3; then compound 1; then compound 2.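

In this assay, cyclohexyloxy in place of ethylamino brings a 39-fold lower number from compound 1 to compound 3 (1.59 log units; beyond the scatter), which shows that the group on this aromatic carbon, ortho to a carbamoyl group and meta to a pyridin-3-yl group, can move the number a long way on the core of compound 1. The swap changes several things at once: a chain with no ring gives way to a six-membered non-aromatic ring of carbon only, the heavy atoms go from 3 to 7, and the one hydrogen-bond donor is lost. No measurement at hand explains why this swap has so large an effect.

The compounds shown leave open whether the lower number follows the ring or the ether oxygen. Ethoxy and cyclohexylamino, each carrying only one part of the swap, lie outside this set, as do smaller rings such as cyclopentyloxy.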